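The source may report more compounds than this note shows. Statements on the series, on what has been measured and on what is new or still open speak of the compounds shown alone.

Measured so far in an ADME assay on a cell-free system (plasma, Homo sapiens) for protein binding:
- compound 1 `CCOc1nc2nc(C)cc(Nc3ccc(C(F)(F)F)cc3)n2n1` gives 92.4% as its value
- compound 2 `Cc1cc(Nc2ccc(S(F)(F)(F)(F)F)cc2)n2nc(C(C)(F)F)nc2n1` gives 97.4% as its value
- compound 3 `CCC(F)(F)c1nc2nc(C)cc(Nc3ccc(S(F)(F)(F)(F)F)cc3)n2n1` gives 97.7% as its value

Compound 1 has the lowest percentage bound of the three and so the highest unbound fraction. Compound 2 and compound 3 both lie beyond the scatter from it.

The next compound to be measured is compound 4 `CCc1nc2nc(C)cc(Nc3ccc(C(F)(F)F)cc3)n2n1` with ethyl in place of ethoxy on an aromatic carbon and the rest of the core of compound 1 unchanged.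

Among the measured compounds shown here, only one measured step bears on this change, and only loosely. That step, a 1.1-fold lower unbound fraction from compound 2 to compound 3 (0.05 log units; within the scatter), puts methyl in place of hydrogen on a saturated chain carbon and stays small. For the measured compounds named here, no measured pair exchanges ethoxy for ethyl. Compound 2 and compound 3 differ from compound 1 in more than one place, so their values give no direct size for this step. As far as these compounds go, no step beyond the scatter is therefore expected, and the direction stays open.

The expected change is a 1.1-fold higher unbound fraction from compound 1 to compound 4 (0.02 log units; within the scatter) as a working estimate. For compound 4 the estimated value is 92% with an expected range from 85% to 96% as its limits of expectation.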

Compound 4, plasma protein binding: 87.5%
Estimate against measurement, compound 4: 1.6-fold (0.19 log units) (unbound fraction) below, within the range that was stated.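

Among the compounds shown here, this is the first measured exchange of the ethoxy group itself on this aromatic carbon of the five-membered aromatic ring: in this assay, ethyl in place of ethoxy gives a 1.6-fold higher unbound fraction from compound 1 to compound 4 (0.22 log units; within the scatter), so removing the oxygen with its hydrogen-bond acceptor leaves the read-out within the scatter while the shared core and the trifluoromethyl group stay in place. The substituent on this carbon has now been changed in two separate pairs, the other being the chain extension with a 1.1-fold lower unbound fraction from compound 2 to compound 3 (0.05 log units; within the scatter), and neither step goes beyond the scatter, though the two pairs carry different groups on the shared core and differ in the kind of change made. No measurement is available that would account for the size of the ethyl for ethoxy step.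

As far as these compounds go, it remains open whether ethyl in place of ethoxy stays as small when the pentafluorosulfanyl group of compound 2 and compound 3 replaces trifluoromethyl. It also remains open how this assay responds to an amine, a carboxylic acid or a longer chain on this same aromatic carbon, since the groups shown here cover only ether and fluorinated or plain alkyl substituents.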